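Swapping the Chlorofuran for a Chlorophenyl Ring

The source may hold more compounds than are shown below. What is called first, only, known or untested is meant among the compounds shown, and "the series" means these compounds.

Compound 1 `N#C/C(=C\c1c[nH]c2ccccc12)C(=O)c1c[nH]c2ccccc12` gives 14000 nM in a functional assay on MIA cells (Homo sapiens) for inhibition, read by MTT assay, with a stated time of 72 h; a lower number here means a stronger inhibitor of growth, a higher number a weaker inhibitor of growth. Compound 2 `COc1ccc(CNC(=O)/C(C#N)=C/c2ccc(Cl)o2)cc1` gives 15000 nM in this assay, the higher of the two numbers, although its gap to compound 1 lies within the scatter. Compound 3 `COc1ccc(CNC(=O)/C(C#N)=C/c2ccc(-c3ccccc3)o2)cc1` reaches only the limit > 100000 nM in this assay. Going by the values given here, the one measured step is an at least 6.6-fold higher number from compound 2 to compound 3 (0.82 log units; beyond the scatter), and one of the three values sits at the limit of > 100000 nM in this assay, at which 1 of the 3 values shown sits.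

Compound 4 `COc1ccc(CNC(=O)/C(C#N)=C/c2ccc(Cl)cc2)cc1` has not yet been measured in this assay. The change from compound 2 is 4-chlorophenyl in place of 5-chlorofuran-2-yl on a double-bonded chain carbon bound to a double-bonded chain carbon. The measured step bears on it only indirectly: it alters the group carried by the furan ring of compound 2 rather than exchanging that ring, and it shows that a much larger aryl end weakens growth inhibition. Among the compounds with values here, the change to compound 4 keeps the chlorine and replaces the five-membered ring with a six-membered one of carbon only, a comparison for which no measured pair exists here. The step of a 1.5-fold higher number from compound 2 to compound 4 (0.17 log units; within the scatter) is therefore expected to stay within or only slightly beyond the scatter, with the uncertainty leaning toward a higher number. Compound 4 is estimated at 22000 nM, between 7000 nM and 80000 nM.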

Compound 4, concentration for 50% growth inhibition: 16000 nM
Compound 4: the middle estimate sits 1.4-fold (0.14 log units) above what was measured; measured number inside the range.
By their numbers in this assay, from the lowest: compounds 1, 2 and 4 (each within the scatter of the next). At a limit, above all of these: compound 3.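

The step of a 1.1-fold higher number from compound 2 to compound 4 (0.03 log units; within the scatter) shows that, in this assay, the ring on a double-bonded chain carbon bound to a double-bonded chain carbon can be exchanged with no change beyond the scatter, provided the chlorine is kept. The earlier step altered only the group carried by the furan ring, whereas this one replaces the ring itself: a five-membered aromatic ring with 1 hetero atom gives way to a six-membered aromatic ring of carbon only, and the hydrogen-bond acceptor counted in 5-chlorofuran-2-yl leaves with it, yet growth inhibition stays at the same level. No measured property of either ring is available here to explain this equivalence.

Going by these compounds, it remains open whether the chlorine itself matters on the six-membered ring, for instance whether an amine or a carboxylic acid in its place would keep the level shared by compound 2 and compound 4. On these data alone, it is also open whether a phenyl group on that ring would weaken growth inhibition as it does on the furan ring of compound 3.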